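The source may hold more compounds than are shown below. What is called first, only, known or untested is meant among the compounds shown, and "the series" means these compounds.

Measured in a functional assay on HCT-116 cells (Homo sapiens) for inhibition, read by sulforhodamine B assay, with a stated time of 72 h; a lower number here means a stronger inhibitor, a higher number a weaker inhibitor:
compound 1 `COc1ccc2cc(C(C)c3nnc4n3N=C(c3ccc([N+](=O)[O-])cc3)CS4)ccc2c1`: 15100 nM
compound 2 `CC(c1ccc(-c2ccccc2)c(F)c1)c1nnc2n1N=C(c1ccc(OC(F)(F)F)cc1)CS2`: 5400 nM

Compound 1 gives the highest number of the two. Compound 2 sits a step away that exceeds the scatter, but the two structures differ in more than one place, so that gap settles nothing about any single change. Compound 3 `COc1ccc2cc(C(C)c3nnc4n3N=C(c3ccc(OC(F)(F)F)cc3)CS4)ccc2c1` differs from compound 1 by trifluoromethoxy in place of nitro on an aromatic carbon. For the measured compounds named here, no measured pair isolates this change. In this assay the estimated step is a 1.9-fold lower number from compound 1 to compound 3 (0.28 log units; within the scatter). Compound 3 is accordingly estimated at 8000 nM, with a range from 3000 nM to 22000 nM.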

Compound 3, half-maximal inhibitory concentration: 11700 nM
Compound 3: the middle estimate sits 1.5-fold (0.17 log units) below what was measured; low and high end bracket the measured number.
By their numbers in this assay, from the lowest: compound 2; then compounds 3 and 1 (each within the scatter of the next).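

In this assay, the change from 4-nitrophenyl to 4-(trifluoromethoxy)phenyl can now be read on its own, as a 1.3-fold lower number from compound 1 to compound 3 (0.11 log units; within the scatter). At this place, para to a large group, the two groups cannot be told apart, so trifluoromethoxy stands in for nitro with no readable change. No available data bear on the reason for this result.

Open, from the compounds shown here alone, is whether an amine or a carboxylic acid in this place would give a number apart from those of compound 1 and compound 3. Also open, going by these compounds, is whether the same change would read alike on the rest of compound 2.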